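Acyl variation at the amide carbonyl: toward compound 4

The source may report more compounds than this note shows. Statements on the series, on what has been measured and on what is new or still open speak of the compounds shown alone.

Compound 1 `COC(=O)C(=O)N[C@@H](CO)C(=O)O` stands at "not determined" (no result reported) in an ADME assay on microsomes from liver (Homo sapiens) for metabolic stability, with a stated time of 30 min; on this read-out higher numbers stand for a more stable compound and lower numbers for a less stable compound. Compound 2 `O=C(CCO)N[C@@H](CO)C(=O)O` gives 96% in this assay, and compound 3 `CC(C)C(=O)N[C@@H](CO)C(=O)O` gives 84%. Compound 3 thus stands lowest of the two numbers in hand, with compound 2 the nearest entry above it, while compound 1 remains the further entry without a single number. Within the data shown here, the one measured step, a number 12 percentage points lower from compound 2 to compound 3 (beyond the scatter), concerns the same carbonyl carbon as the change now considered; it is modest though beyond the scatter, and it is the only step that bears on the question. Compound 4 `O=C(N[C@@H](CO)C(=O)O)C1CC1` differs from compound 3 by cyclopropyl in place of isopropyl on a carbonyl carbon. Among the measured compounds shown here, no measured pair shows this exchange of groups, so the expectation rests on the size of the one known step at this carbonyl carbon and on the scatter of the read-out. A step within the scatter is expected, a number 1 percentage points higher from compound 3 to compound 4 (within the scatter), with no direction favoured. Compound 4 is expected to give 85% in this assay, within the range 70% to 97%.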

Compound 4, percent of the compound remaining: 26%
For compound 4 the middle estimate is 59 percentage points above the measured one; measured number outside the range, below it.
By their numbers in this assay, from the lowest: compound 4; then compound 3; then compound 2.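

In this assay, cyclopropyl in place of isopropyl on this carbonyl carbon gives a number 58 percentage points lower from compound 3 to compound 4 (beyond the scatter), although the count of heavy atoms stays the same and the change lies in the closed three-membered ring. The position is thus far more sensitive than the earlier modest step, a number 12 percentage points lower from compound 2 to compound 3 (beyond the scatter), indicated, and the same holds against the 2-hydroxyethyl group, with a number 70 percentage points lower from compound 2 to compound 4 (beyond the scatter). Nothing in hand accounts for this fall in stability.

On these data alone, it remains open whether the fall belongs to the three-membered ring itself or extends to rings in general, as cyclobutyl or cyclopentyl on the same carbonyl carbon would tell. As far as these compounds go, it is also open whether a branched group such as tert-butyl or a longer chain such as n-butyl would stay near compound 3 or fall toward compound 4.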